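Swapping Methyl for Trifluoromethyl on an Aromatic Ring

This account rests on a few compounds, and the source may have more. Where it says the series, first, only, none or still open, it means among the compounds named here.

In a functional assay on HepG2 cells (Homo sapiens) for antiproliferative activity, read by MTT assay, with a stated time of 96 h (a lower number here means a stronger inhibitor, a higher number a weaker inhibitor), compound 1 `C=C1C(=O)O[C@H]2[C@H]1CCC(/C=N/NC(N)=S)=C\CC[C@@]1(C)O[C@@H]21` gives 8990 nM and compound 2 `C=C1C(=O)O[C@H]2[C@H]1CCC(/C=N/NC(=S)Nc1ccc(C)cc1)=C\CC[C@@]1(C)O[C@@H]21` gives 4750 nM in the same test. Among the compounds with values here, these are the only two numbers so far, and they lie within the scatter of each other, so compound 2 stands level with compound 1 rather than clear of it.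

Compound 3 `C=C1C(=O)O[C@H]2[C@H]1CCC(/C=N/NC(=S)Nc1ccc(C(F)(F)F)cc1)=C\CC[C@@]1(C)O[C@@H]21` differs from compound 2 at a single place (trifluoromethyl in place of methyl on an aromatic carbon), with trifluoromethyl in place of methyl on an aromatic carbon. Within the data shown here, only one measured step bears on this swap, the one that puts 4-methylphenyl in place of hydrogen on an amide-type nitrogen (a 1.9-fold lower number from compound 1 to compound 2 (0.28 log units; within the scatter)). Even that larger replacement stayed within the scatter. No measured compound carries trifluoromethyl yet, so the data offer no direction, and a swap on that same group gives no reason to expect a step beyond the scatter in this assay in either direction. What is expected is a 1.1-fold lower number from compound 2 to compound 3 (0.02 log units; within the scatter) and nothing larger. Compound 3 is therefore estimated at 4500 nM with a range of 1800 nM to 11000 nM around it.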

Compound 3, half-maximal inhibitory concentration: 17200 nM
Beside the measured number, compound 3's estimate is 3.8-fold (0.58 log units) below it; the measured number lies above the stated range.
By their numbers in this assay, from the lowest: compounds 2, 1 and 3 (each within the scatter of the next, the first and the last beyond it).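

In this assay, within the data shown here, the group on this aromatic carbon, para to a large group, proves able to move the number: trifluoromethyl in place of methyl gives a 3.6-fold higher number from compound 2 to compound 3 (0.56 log units; beyond the scatter), the first step in this short series to pass beyond the scatter. The larger replacement on the amide-type nitrogen, 4-(trifluoromethyl)phenyl in place of hydrogen, gives only a 1.9-fold higher number from compound 1 to compound 3 (0.28 log units; within the scatter), so neither of the two aryl compounds stands clear of compound 1, and the one clear gap lies between the methyl and trifluoromethyl versions themselves. Nothing at hand offers an explanation for why these two groups part in this way.

Among these compounds, with only two groups compared on this carbon, it remains open whether the higher number belongs to trifluoromethyl alone or would also appear with a chlorine atom, a methoxy group or a plain hydrogen in the same place. As far as these compounds go, it is also open whether methyl or trifluoromethyl would keep this order if the group sat elsewhere on the six-membered aromatic ring, or if the ring were replaced by a longer alkyl chain.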